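Replacing a chloropropyl chain with a chloroacetyl group

The source may report more compounds than this note shows. Statements on the series, on what has been measured and on what is new or still open speak of the compounds shown alone.

Two ureas built on a shared core have been tested. Compound 1 `CC(C)(C)c1ccc(NC(=O)NCCCCl)cc1` carries a 3-chloropropyl chain on one urea nitrogen and, in a functional assay on HT-29 cells (Homo sapiens) for antiproliferative activity, with a stated time of 48 h (a higher number here means a weaker inhibitor, a lower number a stronger inhibitor), compound 1 gives 28000 nM. Compound 2 `CC(C)(C)c1ccc(CNC(=O)NCCCCl)cc1` inserts a methylene between the aromatic ring and the urea; in this assay compound 2 gives 19000 nM, the lowest of the two numbers, and its gap to compound 1 lies within the usual scatter, so the two cannot be ranked.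

Compound 3 `CC(C)(C)c1ccc(CNC(=O)NC(=O)CCl)cc1` keeps the core of compound 2 but differs in one place: (chloromethyl)carbonyl in place of 3-chloropropyl on an amide-type nitrogen. Among the compounds with values here, no measured pair shows a change of this kind, so there is no step to lean on. The step from compound 2 to compound 3 is expected to be a modest move toward a lower number, a 1.9-fold lower number from compound 2 to compound 3 (0.28 log units; within the scatter), with a broad range on either side. Compound 3 is estimated at 10000 nM, between 1500 nM and 40000 nM.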

Compound 3, half-maximal inhibitory concentration: 7100 nM
Beside the measured number, compound 3's estimate is 1.4-fold (0.15 log units) above it, and the stated range covers the measured number.
By their numbers in this assay, from the lowest: compound 3; then compounds 2 and 1 (each within the scatter of the next).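

On the amide-type nitrogen of the core of compound 2, (chloromethyl)carbonyl in place of 3-chloropropyl gives a 2.7-fold lower number from compound 2 to compound 3 (0.43 log units; beyond the scatter) in this assay. Within the data shown here, this is the first step that lies beyond the usual scatter, whereas compound 1 and compound 2 could not be ranked. It shows that changing the group on this nitrogen can move the antiproliferative number by a modest but readable amount, though nothing measured here explains the shift.

The compounds shown do not tell whether the chlorine is needed, since a plain acetyl group, a longer chloroacyl chain or a terminal amine does not appear among them. They also leave open whether the same change would give a similar step on the core of compound 1, which lacks the extra methylene.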